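Swapping 1-methylheptyl for benzyl on a nitrogen

The source may report more compounds than this note shows. Statements on the series, on what has been measured and on what is new or still open speak of the compounds shown alone.

- compound 1 `CCCN(CCC)c1ccc(NC(=O)c2cc(Cl)ccc2O)c(Cl)c1`: 323000 nM
- compound 2 `O=C(Nc1ccc(NC2CCCC2)cc1Cl)c1cc(Cl)ccc1O`: "not determined" (no result reported)
- compound 3 `CCCCCCC(C)Nc1ccc(NC(=O)c2cc(Cl)ccc2O)c(Cl)c1`: 18600 nM

These numbers come from an ADME assay on A549 cells (Homo sapiens) for cytotoxicity, read by LDH release, with a stated time of 15 h; on this read-out higher numbers stand for lower toxicity in this test and lower numbers for higher toxicity in this test. Of the two compounds with a number, compound 3 stands lowest at 18600 nM. Compound 2 offers no guide.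

Compound 4 `O=C(Nc1ccc(NCc2ccccc2)cc1Cl)c1cc(Cl)ccc1O` differs from compound 3 in one place: benzyl in place of 1-methylheptyl on a nitrogen on an aromatic ring. Within the data shown here, one measured step bears on this place, a 17-fold lower number from compound 1 to compound 3 (1.24 log units; beyond the scatter). It is large, but it involves a different swap, so it shows that changes here can matter without giving a size for this one. Compound 4, like compound 3, keeps a single group on that nitrogen, so only a small rise is expected. The estimate means a 1.6-fold higher number from compound 3 to compound 4 (0.21 log units; within the scatter). For compound 4 the expected value is 30000 nM, with an expected range of 10000 nM to 100000 nM.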

Compound 4, half-maximal cytotoxic concentration: 81300 nM
Beside the measured number, compound 4's estimate is 2.7-fold (0.43 log units) below it, and the stated range covers the measured number.
By their numbers in this assay, from the lowest: compound 3; then compound 4; then compound 1.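

In this assay, the choice of group on this nitrogen matters even when it carries a single group: benzyl in place of 1-methylheptyl gives a 4.4-fold higher number from compound 3 to compound 4 (0.64 log units; beyond the scatter). Benzylamino in place of dipropylamino gives a 4.0-fold lower number from compound 1 to compound 4 (0.60 log units; beyond the scatter), which places compound 4 inside the range set by the other two compounds. Nothing measured here explains either step.

This swap brings in an aromatic ring and removes an open, branched chain at once, so the two changes cannot be told apart. A cyclohexylmethyl group or an unbranched hexyl chain on this nitrogen would help to separate them.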